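The compounds below may be only part of what the source reports. "The series", "measured", "known", "first", "only" and "open" are said of these compounds alone.

Measured so far:
- Compound 1 `Cc1ccc(S(=O)(=O)c2nc3ccccc3nc2Nc2ccc(C(F)(F)F)cc2)cc1`: 2540 nM
- Compound 2 `COc1ccc(Nc2nc3ccccc3nc2S(=O)(=O)c2ccc(OC)cc2)cc1`: 8710 nM
- Compound 3 `COc1ccc(S(=O)(=O)c2nc3ccccc3nc2Nc2ccc(F)cc2)cc1`: 2200 nM

All three numbers come from a functional assay on PC-3 cells (Homo sapiens) for cytotoxicity, read by MTT assay, with a stated time of 72 h; on this read-out higher numbers stand for weaker inhibition and lower numbers for stronger inhibition. Compound 3 gives the lowest number of the three. Its nearest neighbour is compound 1, whose value sits within the usual scatter of that of compound 3, so no order between these two can be claimed. For the measured compounds named here, the only single-point step among the measured compounds is a 4.0-fold lower number from compound 2 to compound 3 (0.60 log units; beyond the scatter), a modest step beyond the scatter.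

Compound 4 `COc1ccc(S(=O)(=O)c2nc3ccccc3nc2Nc2ccc(C(F)(F)F)cc2)cc1` has not yet been measured in this assay. Its difference from compound 3 is trifluoromethyl in place of fluoro on an aromatic carbon. Going by the values given here, no measured step covers this exact change. Compound 1 carries the same trifluoromethyl group, but it also differs from compound 4 elsewhere, so only its value can be set beside that of compound 3: the two numbers lie within the scatter of each other. The step from compound 2 to compound 3 concerns a different exchange and does not bear on this one. On this basis little movement in this assay is expected, in no clear direction, and compound 4 is estimated at 2500 nM, with a likely range of 1200 nM to 5500 nM. That estimate means a step of a 1.1-fold higher number from compound 3 to compound 4 (0.06 log units; within the scatter), which is expected to stay within the scatter.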

Compound 4, half-maximal inhibitory concentration: 330 nM
For compound 4 the middle estimate is 7.6-fold (0.88 log units) above the measured one, and the stated range ends above it.
By their numbers in this assay, from the lowest: compound 4; then compounds 3 and 1 (each within the scatter of the next); then compound 2.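

In this assay, the change from 4-fluorophenyl to 4-(trifluoromethyl)phenyl gives a further clear step (a 6.7-fold lower number from compound 3 to compound 4 (0.82 log units; beyond the scatter)), so this place, para to a large group, stays sensitive to its substituent even after the exchange of methoxy for fluoro. With the methoxy on the other aryl ring held fixed, the three groups at this place now fall in a single order, with trifluoromethyl giving the lowest number and methoxy the highest, and the full span is large (a 26-fold lower number from compound 2 to compound 4 (1.42 log units; beyond the scatter)). The other end of the molecule also matters, a point no earlier single-point pair could show: methoxy in place of methyl on an aromatic carbon gives a step of similar size (a 7.7-fold lower number from compound 1 to compound 4 (0.89 log units; beyond the scatter)), and no supporting data are available to explain any of these steps.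

As far as these compounds go, it remains open whether trifluoromethyl would still give a lower number than fluoro with methyl rather than methoxy at that other end. The compounds shown also leave open how a nitrile, an amine or a carboxylic acid at the place para to the large group would fit into this order.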